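Swapping Cyclopropyl for Fluoro on a Hedgehog Inhibitor Core

The compounds below may be only part of what the source reports. "The series", "measured", "known", "first", "only" and "open" are said of these compounds alone.

Compound 1 `Cc1cnc(Nc2ccc(C(=O)Nc3c(C)cccc3C)cc2)nc1-c1ccc(OC(F)(F)F)cc1`: 1.3 nM
Compound 2 `Cc1cccc(C)c1NC(=O)c1ccc(Nc2ncc(C3CC3)c(-c3ccc(OC(F)(F)F)cc3)n2)cc1`: 1.3 nM

The two measured compounds share one core and differ only in a single group on an aromatic carbon. In an assay on NIH3T3 cells for inhibition of Sonic hedgehog protein (Mus musculus), read by a luciferase reporter, with a stated time of 48 h (on this read-out higher numbers stand for weaker inhibition and lower numbers for stronger inhibition), compound 1 gives 1.3 nM, and compound 2 gives 1.3 nM. The step of no change at the digits printed from compound 1 to compound 2 (within the scatter) shows that putting cyclopropyl in place of methyl at this position changed nothing beyond the scatter. On these numbers compound 2 stands level with compound 1.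

Compound 3 `Cc1cccc(C)c1NC(=O)c1ccc(Nc2ncc(F)c(-c3ccc(OC(F)(F)F)cc3)n2)cc1` has not yet been measured. It differs from compound 2 in one place: fluoro in place of cyclopropyl on an aromatic carbon. Within the data shown here, the only measured step bearing on this position is no change at the digits printed from compound 1 to compound 2 (within the scatter), which was flat. Among the measured compounds shown here, that step involved no fluoro, so it shows only that two groups of different size are accepted here without loss. Compound 3 is therefore expected to show a step of a 1.5-fold higher number from compound 2 to compound 3 (0.19 log units; within the scatter) in this assay, within the scatter. Compound 3 is estimated at 2 nM, with a range from 0.6 nM to 8 nM.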

Compound 3, half-maximal inhibitory concentration: 1.6 nM
Compound 3: the middle estimate sits 1.3-fold (0.10 log units) above what was measured; measured number inside the range.
By their numbers in this assay, from the lowest: compounds 1, 2 and 3 (each within the scatter of the next).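

In this assay fluoro in place of cyclopropyl gives a 1.2-fold higher number from compound 2 to compound 3 (0.09 log units; within the scatter) and fluoro in place of methyl gives a 1.2-fold higher number from compound 1 to compound 3 (0.09 log units; within the scatter) at the same aromatic carbon. The earlier compounds shown here held only carbon groups here, so compound 3 adds something new: a single fluorine atom is accepted at this position as well, with no loss beyond the scatter. No measurement shown explains why these three groups read alike.

The compounds shown leave open whether this position would stay as flat with an amine, a carboxylic acid or a longer chain such as hexyl. They also leave open whether the same holds once the neighbouring 4-(trifluoromethoxy)phenyl group, common to all three compounds, is replaced.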